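This account rests on a few compounds, and the source may have more. Where it says the series, first, only, none or still open, it means among the compounds named here.

Compound 2 `O=C(/C=C/c1cc2ccccc2[nH]c1=O)c1ccc(O)cc1` gives 66300 nM in an ADME assay on SK-MEL-28 cells (Homo sapiens) for cytotoxicity, read by sulforhodamine B assay, with a stated time of 24 h; on this read-out higher numbers stand for lower toxicity in this test and lower numbers for higher toxicity in this test. Its methoxy partner, compound 1 `COc1ccc(C(=O)/C=C/c2cc3ccccc3[nH]c2=O)cc1`, reaches only a limit of this assay, > 100000 nM. Compound 2 thus holds the single measured figure in the series, the other result being a limit (the limit of > 100000 nM in this assay, at which 1 of the 2 values shown sits). Between the two, an at least 1.5-fold lower number from compound 1 to compound 2 (0.17 log units; that floor lies within the scatter), a step that falls within the usual scatter.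

Compound 3 `O=C(/C=C/c1cc2ccccc2[nH]c1=O)c1ccc(Cl)cc1` is not yet measured and differs from compound 2 by chloro in place of hydroxy on an aromatic carbon. Among the compounds with values here, no measured step bears directly on this exchange; the only step in hand, methyl to hydrogen on the ring oxygen, did not move the read-out beyond scatter. Nothing in the data points to a change in either direction, so no step beyond the scatter is expected in this assay. Compound 3 is therefore expected to give 60000 nM, with a range of 20000 nM to 150000 nM, which means an expected 1.1-fold lower number from compound 2 to compound 3 (0.04 log units; within the scatter).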

Compound 3, concentration lethal to 50% of the cells: > 100000 nM
Compound 3: only a limit was reported; the forecaster's own chance of this, stated with the estimate: 35%; middle value at least 1.6-fold (0.22 log units) from the limit.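

The 4-hydroxyphenyl to 4-chlorophenyl exchange in this assay gives an at least 1.5-fold higher number from compound 2 to compound 3 (0.17 log units; that floor lies within the scatter), so the printed floor does not place this change beyond the scatter, although the true step could be larger. The step between the methoxy and chloro compounds cannot be read, since both results are limits. With a second compound at the limit, compound 2, the only one of the three carrying a hydroxy group, remains the only one with a number, and that number cannot yet be separated from the limit: the limit of > 100000 nM in this assay, at which 2 of the 3 values shown sit.

On these data alone, how far compound 1 and compound 3 lie past the limit remains open, and with it the true size of both steps from compound 2. Also open, as far as these compounds go, is whether an amine or a carboxylic acid at this position would give a number clearly lower than that of compound 2 in this assay.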